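The compounds below may be only part of what the source reports. "The series", "measured", "known", "first", "only" and "open" are said of these compounds alone.

Measured in a functional assay on MCF7 cells (Homo sapiens) for antiproliferative activity, read by MTT assay, with a stated time of 48 h; on this read-out higher numbers stand for weaker inhibition and lower numbers for stronger inhibition:
- compound 1 `CC(=O)N1N=C(c2ccc3ccccc3c2)OC1c1cccc(Br)c1`: 2.34 ug/mL
- compound 2 `CC(=O)N1N=C(c2ccc3ccccc3c2)OC1c1ccccc1F`: 3.44 ug/mL

Within the data shown here, with only two numbers so far, compound 2 at 3.44 ug/mL has a single neighbour, and the two values lie within the scatter of each other. The next compound is compound 3 `CC(=O)N1N=C(c2ccc3ccccc3c2)OC1c1ccccc1[N+](=O)[O-]`, which has nitro in place of fluoro on an aromatic carbon, ortho to a large group: nitro in place of fluoro on an aromatic carbon. Among the measured compounds shown here, the one measured step is a 1.5-fold higher number from compound 1 to compound 2 (0.17 log units; within the scatter), and it also changes the substituent on that aromatic ring. For the measured compounds named here, no measured step brings in nitro, so this is weak guidance. With nothing else to go on, no shift beyond the scatter is expected in this assay. The estimated step is a 1.1-fold lower number from compound 2 to compound 3 (0.06 log units; within the scatter). For compound 3 the expected value is 3 ug/mL, with an estimated range from 1.2 ug/mL to 8 ug/mL.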

Compound 3, half-maximal inhibitory concentration: 18.2 ug/mL
The estimate for compound 3 lay 6.1-fold (0.78 log units) below the measured number; the whole stated range lies below it.
By their numbers in this assay, from the lowest: compounds 1 and 2 (each within the scatter of the next); then compound 3.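

In this assay the substituent on this aromatic carbon, ortho to a large group, now makes a difference beyond the scatter: nitro in place of fluoro gives a clear rise in the number (a 5.3-fold higher number from compound 2 to compound 3 (0.72 log units; beyond the scatter)), which the earlier pair, lying within the scatter of each other, could not show. The 2-nitrophenyl compound also stands apart from the 3-bromophenyl compound (a 7.8-fold higher number from compound 1 to compound 3 (0.89 log units; beyond the scatter)), so in this set of three only the nitro compound separates from the others. No measurement at hand bears on what lies behind this rise.

As far as these compounds go, whether the rise is specific to nitro or would recur with an amine or a methoxy on the same carbon stays open. Also open, from the compounds shown here alone, is how nitro would read at the place the bromo occupies in compound 1.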